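Replacing 4-nitrophenyl on the acetylated core

The source may hold more compounds than are shown below. What is called first, only, known or untested is meant among the compounds shown, and "the series" means these compounds.

Measured so far in a functional assay on Bel-7402 cells (Homo sapiens) for cytotoxicity, read by MTT assay, with a stated time of 48 h; on this read-out higher numbers stand for weaker inhibition and lower numbers for stronger inhibition
compound 1 `COc1ccc(-c2c[nH]c(=O)n2-c2cc(OC)c(OC)c(OC)c2)cc1` gives "not determined" (no result reported)
compound 2 `COc1ccc(-c2c[nH]c(=O)n2-c2cc(OC)c(OC)c(OC)c2)cc1[N+](=O)[O-]` gives "not determined" (no result reported)
compound 3 `COc1cc(-n2c(-c3ccc([N+](=O)[O-])cc3)cn(C(C)=O)c2=O)cc(OC)c1OC` gives > 50000 nM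

In this assay compound 3 gives > 50000 nM, which is a limit of the assay and not a number. The record so far amounts to the limit of > 50000 nM in this assay, at which 1 of the 3 values shown sits, and compound 1 and compound 2 offer no reading for comparison.

Next comes compound 4 `COc1ccc(-c2cn(C(C)=O)c(=O)n2-c2cc(OC)c(OC)c(OC)c2)cc1N`, with 3-amino-4-methoxyphenyl in place of 4-nitrophenyl on an aromatic carbon. No measured step sizes this change, so the expectation stays loose. Since compound 3 reads > 50000 nM, any number reported for compound 4 would have to lie toward stronger inhibition. The expected change is an at least 10-fold lower number from compound 3 to compound 4 (1.00 log units; beyond the scatter), and it is poorly bounded. For compound 4 the estimated value is 5000 nM, with an expected range from 300 nM to 50000 nM.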

Compound 4, half-maximal inhibitory concentration: 600 nM
Estimate against measurement, compound 4: 8.3-fold (0.92 log units) above, and the stated range covers the measured number.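

On the acetylated core, this aromatic carbon carries the only number shown: in this assay compound 4 gives 600 nM with 3-amino-4-methoxyphenyl in place of 4-nitrophenyl. Compound 3 gives > 50000 nM as a limit of the assay and not a number. The change brings an at least 83-fold lower number from compound 3 to compound 4 (1.92 log units; beyond the scatter) and that step is bounded on one side only: the limit of > 50000 nM in this assay, at which 1 of the 4 values shown sits.

The amino and methoxy groups enter together, so the step cannot be assigned to either one alone. An acetamide or a hydroxyl in place of the amino group would help to separate them.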